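Swapping a cycloheptyl for a 2-methoxyethyl on the amide

The compounds below may be only part of what the source reports. "The series", "measured", "known", "first", "only" and "open" are said of these compounds alone.

Compound 1, `Cc1cc(C)c2cc(C(=O)NC3CCN(C)CC3)[nH]c2c1`, in a physicochemical assay for solubility, measured as thermodynamic solubility, with a stated time of 24 h, at pH 6.8 (a lower number here means a less soluble compound, a higher number a more soluble compound), gives > 10000000 nM; that value is a limit of this assay. Compound 2, `Cc1cc(C)c2cc(C(=O)NC(C)C)[nH]c2c1`, gives 20000 nM. Compound 3, `Cc1cc(C)c2cc(C(=O)NC3CCCCCC3)[nH]c2c1`, gives < 4000 nM, which is again a limit of this assay.

Compound 3 therefore sits at the low edge of what this assay reports, as the limit of < 4000 nM in this assay, at which 1 of the 3 values shown sits, makes plain, while compound 1 sits at the opposite edge, (the limit of > 10000000 nM in this assay, at which 1 of the 3 values shown sits). Compound 4, `COCCNC(=O)c1cc2c(C)cc(C)cc2[nH]1`, differs from compound 3 in one place: 2-methoxyethyl in place of cycloheptyl on an amide-type nitrogen. Going by the values given here, two measured steps bear on it, both ending at compound 3: an at least 5.0-fold lower number from compound 2 to compound 3 (0.69 log units; beyond the scatter) and an at least 2500-fold lower number from compound 1 to compound 3 (3.39 log units; beyond the scatter). Both show that leaving the cycloheptyl for a smaller or more polar group went with a higher number, so a step upward is expected for compound 4, estimated as an at least 12-fold higher number from compound 3 to compound 4 (1.09 log units; beyond the scatter). Compound 4 is expected to give about 50000 nM, with a range from 10000 nM to 300000 nM.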

Compound 4, solubility: 620000 nM
The estimate for compound 4 lay 12-fold (1.09 log units) below the measured number, outside the stated range (above it).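

In this assay, going by these compounds alone, the earlier compounds showed the number rising from cycloheptyl to isopropyl to 1-methylpiperidin-4-yl on this amide-type nitrogen; compound 4 adds that a group with no ring, 2-methoxyethyl with its one hydrogen-bond acceptor, can go well past isopropyl, with a 31-fold higher number from compound 2 to compound 4 (1.49 log units; beyond the scatter). Leaving cycloheptyl for 2-methoxyethyl gives an at least 150-fold higher number from compound 3 to compound 4 (2.19 log units; beyond the scatter), and this step starts from a limit of the assay: the limit of < 4000 nM in this assay, at which 1 of the 4 values shown sits. Even so, 2-methoxyethyl does not match 1-methylpiperidin-4-yl, with an at least 16-fold lower number from compound 1 to compound 4 (1.20 log units; beyond the scatter), and this step also starts from a limit of the assay: the limit of > 10000000 nM in this assay, at which 1 of the 4 values shown sits.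

The compounds shown do not separate the effect of the oxygen in 2-methoxyethyl from that of the chain itself; an n-butyl chain, with carbon in place of that oxygen, would be the direct comparison. As far as these compounds go, how a carboxylic acid at this place would compare also remains open.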